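The source may report more compounds than this note shows. Statements on the series, on what has been measured and on what is new or still open speak of the compounds shown alone.

Working notes on a small series measured in a functional assay on SW1573 cells (Homo sapiens) for inhibition, read by sulforhodamine B assay, with a stated time of 48 h; a higher number here means a weaker inhibitor of growth, a lower number a stronger inhibitor of growth. Compound 1 has the structure `COC(=O)[C@@]1(C)CCC=C2[C@@H]1CC[C@@H](C)[C@]2(C)Cc1c[nH]c2ccc(C)cc12` and in this assay compound 1 gives 15000 nM. Compound 2, `COC(=O)[C@@]1(C)CCC=C2[C@@H]1CC[C@@H](C)[C@]2(C)Cc1c[nH]c2ccc(Br)cc12`, differs from compound 1 by bromo in place of methyl on an aromatic carbon and in this assay compound 2 gives 12000 nM; the step is a 1.3-fold lower number from compound 1 to compound 2 (0.10 log units; within the scatter). Compound 3, `COC(=O)[C@@]1(C)CCC=C2[C@@H]1CC[C@@H](C)[C@]2(C)Cc1c(C)[nH]c2ccc(C)cc12`, differs from compound 1 by methyl in place of hydrogen on an aromatic carbon and in this assay compound 3 gives 18000 nM; the step is a 1.2-fold higher number from compound 1 to compound 3 (0.08 log units; within the scatter). All three values lie within the scatter of one another, so no ordering among compound 1, compound 2 and compound 3 is supported.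

Compound 4, `COC(=O)[C@@]1(C)CCC=C2[C@@H]1CC[C@@H](C)[C@]2(C)Cc1c(C)[nH]c2ccc(Br)cc12`, is not yet measured. It differs from compound 3 by bromo in place of methyl on an aromatic carbon. The two cores differ by methyl in place of hydrogen on an aromatic carbon. The place of the change is the same, word for word, as from compound 1 to compound 2, so the change is the same, made on the core of compound 3 instead of the core of compound 1. Because a 1.3-fold lower number from compound 1 to compound 2 (0.10 log units; within the scatter) lies within the scatter, the step expected is a 1.3-fold lower number from compound 3 to compound 4 (0.11 log units; within the scatter), also within the scatter. Compound 4 is expected to give about 14000 nM, likely between 7000 nM and 28000 nM.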

Compound 4, concentration for 50% growth inhibition: 14000 nM
The estimate for compound 4 equals the measured number at the digits printed; the measured number falls inside the stated range.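

In this assay, bromo in place of methyl on an aromatic carbon gives a 1.3-fold lower number from compound 3 to compound 4 (0.11 log units; within the scatter), which matches the same change on the core of compound 1: the same change on two cores in this assay, a 1.3-fold lower number (0.10 log units; within the scatter) from compound 1 to compound 2 and a 1.3-fold lower number (0.11 log units; within the scatter) from compound 3 to compound 4, 1.0-fold (0.01 log units) apart, within the scatter of two such steps. Methyl in place of hydrogen on an aromatic carbon gives a 1.2-fold higher number from compound 2 to compound 4 (0.07 log units; within the scatter), and this change also reads alike on both cores: the same change on two cores in this assay, a 1.2-fold higher number (0.08 log units; within the scatter) from compound 1 to compound 3 and a 1.2-fold higher number (0.07 log units; within the scatter) from compound 2 to compound 4, 1.0-fold (0.01 log units) apart, within the scatter of two such steps. Among these compounds, this shows only that neither change leaves the scatter on either core, so the four compounds agree with carrying a change across but do not test it, since no step here is large enough to show whether a real effect would carry over.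

The compounds shown leave open whether any change to this series gives a step beyond the scatter, and whether such a step would hold from one core to another. An amine or a longer chain in place of bromo, or a carboxylic acid in place of the methyl ester, would be among the open cases.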